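Swapping the aryl ether group on a thiazolidinedione agonist

The compounds below may be only part of what the source reports. "The series", "measured", "known", "first", "only" and "open" are said of these compounds alone.

Compound 1 `O=C1NC(=O)C(Cc2ccc(Oc3cccc(Cl)c3)cc2)S1`: 318 nM
Compound 2 `Cc1cccc(Oc2ccc(CC3SC(=O)NC3=O)cc2)n1`: 2620 nM

In a functional assay for agonist activity at Free fatty acid receptor 1 (Homo sapiens), read by FLIPR, in the presence of a further agent that is not named here (a higher number here means that more compound is needed for the effect, a lower number that less compound is needed), compound 2 stands highest of the two numbers measured. Among the compounds with values here, the only step known, an 8.2-fold higher number from compound 1 to compound 2 (0.92 log units; beyond the scatter), is modest but beyond the scatter. Compound 3 `O=C1NC(=O)C(Cc2ccc(Oc3ccccc3Cl)cc2)S1` differs from compound 2 by 2-chlorophenyl in place of 6-methylpyridin-2-yl on an oxygen on an aromatic ring. This returns to a chlorophenyl ether, as in compound 1, which gives 318 nM in this assay; the chlorophenyl is a different one, so the size of the step is uncertain. Compound 3 is therefore expected to give a lower number, a 5.2-fold lower number from compound 2 to compound 3 (0.72 log units; beyond the scatter), with an estimated 500 nM in a range from 150 nM to 1600 nM.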

Compound 3, half-maximal effective concentration: 1190 nM
Compound 3: the middle estimate sits 2.4-fold (0.38 log units) below what was measured, within the range that was stated.
By their numbers in this assay, from the lowest: compound 1; then compound 3; then compound 2.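

In this assay, the place of the chlorine on the phenyl ether clearly counts, since the 2-chlorophenyl group does worse than the 3-chlorophenyl group (a 3.7-fold higher number from compound 1 to compound 3 (0.57 log units; beyond the scatter)). The 2-chlorophenyl group still gives a lower number than the 6-methylpyridin-2-yl group (a 2.2-fold lower number from compound 2 to compound 3 (0.34 log units; beyond the scatter)), so it recovers only part of the loss seen with that group. Nothing available explains these differences. On these data alone, whether the chlorine helps at all remains open, as a plain phenyl group would be needed to tell. A methoxy group in place of the chlorine is also untested among the compounds shown.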